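Swapping chloro for cyano in a series of cytotoxic compounds

The compounds below may be only part of what the source reports. "The series", "measured", "known", "first", "only" and "open" are said of these compounds alone.

Among the measured compounds shown here, the compounds measured so far in a functional assay on HeLa cells (Homo sapiens) for cytotoxicity, read by MTT assay, with a stated time of 24 h (a higher number here means a weaker inhibitor, a lower number a stronger inhibitor), share a core. Compound 1 `CN1C/C(=C\c2ccc(C(C)(C)C)cc2)C(=O)/C(=C/c2ccccc2F)C1` gives 15500 nM there. Compound 2 `COc1cc(/C=C2\CN(C)C/C(=C\c3ccc(Cl)cc3)C2=O)cc(OC)c1` gives 11200 nM in the same test. Compound 3 `COc1cc(/C=C2\CN(C)C/C(=C\c3ccc(Cl)cc3)C2=O)cc(OC)c1OC` reads > 20000 nM and this is a limit of the assay, not a number. Its place is therefore known only as the limit of > 20000 nM in this assay, at which 1 of the 3 values shown sits, and no exact value can be given for it.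

Compound 4 `COc1cc(/C=C2\CN(C)C/C(=C\c3ccc(C#N)cc3)C2=O)cc(OC)c1OC` departs from compound 3 by a single change, cyano in place of chloro on an aromatic carbon, para to a large group cyano in place of chloro on an aromatic carbon and nothing else. For the measured compounds named here, no measured step makes this exchange. The nearest evidence is a different change, methoxy in place of hydrogen on an aromatic carbon, which gives an at least 1.7-fold higher number from compound 2 to compound 3 (0.25 log units; that floor lies within the scatter) and so offers no step beyond the scatter as a guide.

No step beyond the scatter is therefore expected in this assay and no direction can be named. The expectation is anchored on compound 3 with its limit of > 20000 nM as the starting point. The expected step is a number no higher from compound 3 to compound 4 (the limit leaves the size open) with an even chance of another limit. For compound 4 the estimate is 20000 nM with an expected range from 9000 nM to 45000 nM in this read-out.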

Compound 4, half-maximal inhibitory concentration: 3420 nM
Compound 4: middle estimate off by 5.8-fold (0.77 log units), on the high side, outside the stated range (below it).
By their numbers in this assay, from the lowest: compound 4; then compounds 2 and 1 (each within the scatter of the next). At a limit, above all of these: compound 3.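

In this assay the exchange of chloro for cyano gives an at least 5.8-fold lower number from compound 3 to compound 4 (0.76 log units; beyond the scatter), and it is the only step among the compounds shown that lies beyond the scatter. Among the compounds shown here, the one earlier step, an at least 1.7-fold higher number from compound 2 to compound 3 (0.25 log units; that floor lies within the scatter), concerned methoxy in place of hydrogen and showed nothing beyond the scatter, so this is the first sign that the group on this aromatic carbon, para to a large group, bears on the reading. The true size of the step stays unknown, since compound 3 stands at a limit of the assay and not at a number: the limit of > 20000 nM in this assay, at which 1 of the 4 values shown sits.

From the compounds shown here alone, with a single exchange at this place, it remains open whether cyano is special there or whether other groups, such as an amine or a carboxylic acid, would read the same way. Also open, going by these compounds, is whether cyano in place of chloro would give a step of like size on compound 2, whose value of 11200 nM is a number and not a limit, and which could therefore fix that size.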